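Bromo to Cyano on the Thioether Aryl Ring

The source may hold more compounds than are shown below. What is called first, only, known or untested is meant among the compounds shown, and "the series" means these compounds.

Compound 2, `OC[C@H]1O[C@@H](n2cnc3c(CSc4ccc(Br)cc4)ncnc32)[C@H](O)[C@@H]1O`: 178 nM
Compound 1, `OC[C@H]1O[C@@H](n2cnc3c(CSc4cccc(I)c4)ncnc32)[C@H](O)[C@@H]1O`: 245 nM

Compound 2 holds the lowest of the two numbers recorded in an assay on isolated protein for binding affinity to Equilibrative nucleoside transporter 1 (Homo sapiens); a higher number here means a weaker inhibitor, a lower number a stronger inhibitor. Within the data shown here, its only neighbour is compound 1, and the step from compound 1 to compound 2, a 1.4-fold lower number from compound 1 to compound 2 (0.14 log units; within the scatter), stays within the scatter, so the two cannot be ranked.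

Compound 3, `N#Cc1ccc(SCc2ncnc3c2ncn3[C@@H]2O[C@H](CO)[C@@H](O)[C@H]2O)cc1`, differs from compound 2 in one place: cyano in place of bromo on an aromatic carbon. Among the measured compounds shown here, no measured step exchanges a halogen for a nitrile. For the measured compounds named here, the single step at hand, a 1.4-fold lower number from compound 1 to compound 2 (0.14 log units; within the scatter), only moved a halogen around the ring and left the number essentially unchanged, so it offers no direction for the new change. The expectation for compound 3 is therefore a step no larger than the scatter, a 1.4-fold higher number from compound 2 to compound 3 (0.15 log units; within the scatter), with wide uncertainty. Compound 3 is estimated at 250 nM, in the range 80 nM to 800 nM.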

Compound 3, half-maximal inhibitory concentration: 81.3 nM
For compound 3 the middle estimate is 3.1-fold (0.49 log units) above the measured one, and the stated range covers the measured number.
By their numbers in this assay, from the lowest: compound 3; then compounds 2 and 1 (each within the scatter of the next).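

In this assay, among these compounds, replacing bromo with cyano on this aromatic carbon gives the first step beyond the scatter (a 2.2-fold lower number from compound 2 to compound 3 (0.34 log units; beyond the scatter)). The comparison with the 3-iodophenyl compound points the same way (a 3.0-fold lower number from compound 1 to compound 3 (0.48 log units; beyond the scatter)), so compound 3 has the lowest number of the three, while the two halogen-bearing compounds cannot be ranked against each other. No measurement shown here explains this modest improvement.

The compounds leave open whether the improvement is specific to the nitrile or would also appear with other groups on the same ring carbon, such as an amine, a carboxylic acid or a methoxy group. They also leave open whether a nitrile would give a similar number at the ring position held by the iodine in compound 1.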